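Cyclopentyl for Cyclopropyl on the Sulfonyl: Expected Exposure

A few compounds are considered here, and "the series" means these few. Any claim that something is new, unique, unknown or untested is made for them only; others in the source may bear on it.

Compound 1 `Cc1sc(N(CC2CC2)[C@H](C)c2ccc(-c3cc(Cl)ccc3-c3nc(=O)o[nH]3)cc2)nc1C(=O)O` in an ADME assay on the whole organism (Macaca fascicularis) for pharmacokinetics, at a dose of 1 mg/kg by the oral route; on this read-out lower numbers stand for lower exposure and higher numbers for higher exposure at the dose given: 1260 nM
Compound 2 `Cc1sc(N(CC2CC2)[C@H](C)c2ccc(-c3cc(Cl)ccc3-c3nc(=O)o[nH]3)cc2)nc1C(=O)NS(=O)(=O)C1CC1` in this assay: 1970 nM

Compound 2 holds the highest of the two numbers shown, with compound 1 nearest, the step being a 1.6-fold higher number from compound 1 to compound 2 (0.19 log units; within the scatter). Compound 3 `Cc1sc(N(CC2CC2)[C@H](C)c2ccc(-c3cc(Cl)ccc3-c3nc(=O)o[nH]3)cc2)nc1C(=O)NS(=O)(=O)C1CCCC1` differs from compound 2 by cyclopentyl in place of cyclopropyl on a sulfonyl sulfur. Going by the values given here, no measured step touches this ring; the single step from compound 1 to compound 2 changed a different place and stayed within the scatter, so nothing argues for a shift beyond the scatter here. Compound 3 is therefore expected to give about 2000 nM in this assay, between 900 nM and 4500 nM. That estimate means a 1.0-fold higher number from compound 2 to compound 3 (0.01 log units; within the scatter).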

Compound 3, maximal plasma concentration: 1120 nM
Beside the measured number, compound 3's estimate is 1.8-fold (0.25 log units) above it; the measured number falls inside the stated range.
By their numbers in this assay, from the lowest: compounds 3, 1 and 2 (each within the scatter of the next).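

Moving from the three-membered to the five-membered carbon ring on the sulfonyl sulfur gives a 1.8-fold lower number from compound 2 to compound 3 (0.25 log units; within the scatter) in this assay, the first measured step at this ring. With the cyclopentyl group in place, swapping the hydroxy group on the carbonyl for the sulfonyl-bearing amino group gives a 1.1-fold lower number from compound 1 to compound 3 (0.05 log units; within the scatter), so this sulfonyl variant also stays within the scatter of the hydroxy compound. No evidence is available to account for these numbers.

The compounds shown leave open whether a methyl or a cyclohexyl group on the sulfonyl sulfur would also stay within the scatter. They also leave open what an amine on the cyclopentyl ring would do to exposure.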